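This account rests on a few compounds, and the source may have more. Where it says the series, first, only, none or still open, it means among the compounds named here.

Compound 1 `COc1nn(Cc2ccccc2N)c(=O)o1` and compound 2 `COc1nn(Cc2ccc(N)cc2)c(=O)o1` are built from the same atoms joined differently; the difference between the two cores is not broken down here. In an assay on COS-7 cells for inhibition of Fatty-acid amide hydrolase 1 (Homo sapiens), read by scintillation counting, with a stated time of 10 min, tested at 10 uM (on this read-out lower numbers stand for less inhibition and higher numbers for more inhibition at the one concentration tested (going by the name of the read-out)), compound 1 gives 8%, while compound 2 gives 34%, the highest of the three measured numbers. Compound 3 `COc1nn(Cc2ccccc2NC(C)=O)c(=O)o1` carries acetyl in place of hydrogen on a nitrogen on an aromatic ring, and in this assay compound 3 gives 11%, so that the step is a number 3 percentage points higher from compound 1 to compound 3 (within the scatter). Compound 4 `COc1nn(Cc2ccc(NC(C)=O)cc2)c(=O)o1` has not yet been measured; it bears acetyl in place of hydrogen on a nitrogen on an aromatic ring, the same change, made at the same kind of place, as that leading from compound 1 to compound 3. Because the step of a number 3 percentage points higher from compound 1 to compound 3 (within the scatter) stayed small, a step of similar size is expected here, estimated as a number 1 percentage points lower from compound 2 to compound 4 (within the scatter). Compound 4 is therefore expected to give about 33% in this assay, most likely between 18% and 48%.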

Compound 4, a percentage reported as inhibition, at one concentration (the size of the read-out at that concentration, not a potency): 37%
Compound 4: the middle estimate sits 4 percentage points below what was measured; measured number inside the range.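

In this assay, acetyl in place of hydrogen on the nitrogen gives a step of a number 3 percentage points higher from compound 2 to compound 4 (within the scatter), and set beside the earlier case, the change carries over from one core to the other without a gap between the two steps: the same change on two cores in this assay, a number 3 percentage points higher (within the scatter) from compound 1 to compound 3 and a number 3 percentage points higher (within the scatter) from compound 2 to compound 4, 0 percentage points apart, within the scatter of two such steps. On these two cores, then, amino to acetamido leaves the read-out within the scatter both times. This does not show that the same would hold on any other core, and each step rests on a single percentage at one concentration, not on a potency.

The compounds shown leave open what a longer acyl chain, a methanesulfonyl group or a carboxylic acid would do on this nitrogen.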